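Piperidine to Piperazine on the Ether Chain

The source may report more compounds than this note shows. Statements on the series, on what has been measured and on what is new or still open speak of the compounds shown alone.

For the measured compounds named here, in a functional assay on A549 cells (Homo sapiens) for inhibition, read by MTT assay, with a stated time of 72 h (on this read-out higher numbers stand for weaker inhibition and lower numbers for stronger inhibition), compound 2 `COc1cc2c(Oc3ccc(NC(=O)c4nn(-c5cccc(F)c5)c(=O)cc4C)cc3F)ccnc2cc1OCCCN1CCC(C)CC1` gives 250 nM, the lowest of the two numbers known, while compound 1 `COc1cc2c(Oc3ccc(NC(=O)c4nn(-c5ccccc5C)c(=O)cc4C)cc3F)ccnc2cc1OCCCN1CCN(C)CC1` gives 2830 nM, a gap beyond the scatter. Going by the values given here, these two differ in more than one place, so no single step joins them. Compound 3 `COc1cc2c(Oc3ccc(NC(=O)c4nn(-c5cccc(F)c5)c(=O)cc4C)cc3F)ccnc2cc1OCCCN1CCN(C)CC1` carries 4-methylpiperazin-1-yl in place of 4-methylpiperidin-1-yl on a saturated chain carbon, three bonds along the chain from an oxygen on an aromatic ring. Compound 1 also bears 4-methylpiperazin-1-yl yet differs from compound 2 elsewhere as well, so the ring exchange alone cannot be read off. A modest loss in this assay is expected, a 2.2-fold higher number from compound 2 to compound 3 (0.34 log units; beyond the scatter). Compound 3 is therefore estimated at 550 nM, within 150 nM to 2000 nM.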

Compound 3, half-maximal inhibitory concentration: 150 nM
For compound 3 the middle estimate is 3.7-fold (0.56 log units) above the measured one; the measured number falls inside the stated range.
By their numbers in this assay, from the lowest: compounds 3 and 2 (each within the scatter of the next); then compound 1.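

In this assay, 4-methylpiperazin-1-yl in place of 4-methylpiperidin-1-yl on the saturated chain carbon gives a 1.7-fold lower number from compound 2 to compound 3 (0.22 log units; within the scatter), so this position tolerates the ring exchange with the 3-fluorophenyl group in place. With 4-methylpiperazin-1-yl held constant, 3-fluorophenyl in place of 2-methylphenyl on the aromatic nitrogen gives a 19-fold lower number from compound 1 to compound 3 (1.28 log units; beyond the scatter), so the large step lies at that nitrogen rather than in the chain ring. Nothing measured here explains either step. The compounds shown leave open how a morpholine on the chain, or an unsubstituted phenyl on the aromatic nitrogen, would read in this assay.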